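A Methyl Group Added to an Inactive Compound

This account rests on a few compounds, and the source may have more. Where it says the series, first, only, none or still open, it means among the compounds named here.

In a functional assay on MCF7 cells (Homo sapiens) for antiproliferative activity, read by MTT assay, with a stated time of 72 h (on this read-out higher numbers stand for weaker inhibition and lower numbers for stronger inhibition), compound 1 (`C=CC/N=C1\S/C(=C\c2ccc(OC)cc2)C(=O)N1C`) gives > 100000 nM, which is a limit of the assay and not a number. Compound 2 (`C=C1CN/C(=N/c2ccccc2)S1`) gives > 100000 nM, and this too is only a limit. The whole picture so far is the limit of > 100000 nM in this assay, at which 2 of the 2 values shown sit. Compound 3 (`C=C1CN(C)/C(=N/c2ccccc2)S1`) differs from compound 2 in one place: methyl in place of hydrogen on an amine nitrogen in a ring. Among the measured compounds shown here, no measured step is available to show what such a change does. Compound 2 offers only its limit of > 100000 nM, so no change beyond the scatter is expected in this assay, and a further limit would be the likeliest report. The expected step is a number no higher from compound 2 to compound 3 (the limit leaves the size open). For compound 3 the estimated value is 100000 nM, with an expected range of 30000 nM to 150000 nM.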

Compound 3, half-maximal inhibitory concentration: > 100000 nM
Compound 3 ended at the assay's limit; the forecaster's own chance of this, stated with the estimate: 80%; the middle value lies on the limit itself.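

In this assay compound 2 and compound 3 both give only a limit, so no step can be read for methyl in place of hydrogen on an amine nitrogen in a ring. The compounds shown leave open what real potency, if any, lies behind these limits, and whether this methyl alters it.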